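This account rests on a few compounds, and the source may have more. Where it says the series, first, only, none or still open, it means among the compounds named here.

Values in a functional assay on Huh-5-2 cells (Homo sapiens), read by MTT assay (on this read-out lower numbers stand for higher toxicity in this test and higher numbers for lower toxicity in this test), follow
Compound 1 (`CC(=O)c1ccc(-c2ccc(Cl)cc2)c(COc2ccc(-c3nc4cc(C(=O)O)ccc4n3C3CCCCC3)cc2)c1`) gives 24000 nM
Compound 2 (`O=C(O)c1ccc(-c2ccc(Cl)cc2)c(COc2ccc(-c3nc4cc(C(=O)O)ccc4n3C3CCCCC3)cc2)c1`) gives > 50000 nM as a limit of the assay
Compound 3 (`CNC(=O)c1ccc(-c2ccc(Cl)cc2)c(COc2ccc(-c3nc4cc(C(=O)O)ccc4n3C3CCCCC3)cc2)c1`) gives 25000 nM

Going by the values given here, compound 3 sits within the scatter of compound 1, the only other plain number here. Compound 4 (`CN(C)C(=O)c1ccc(-c2ccc(Cl)cc2)c(COc2ccc(-c3nc4cc(C(=O)O)ccc4n3C3CCCCC3)cc2)c1`) differs from compound 3 by methyl in place of hydrogen on an amide-type nitrogen. Among the compounds with values here, no measured step touches that nitrogen directly. The nearest evidence comes from the same carbonyl carbon: methylamino in place of methyl gave a step within the scatter (a 1.0-fold higher number from compound 1 to compound 3 (0.02 log units; within the scatter)), and hydroxy in place of methyl gave a larger one that ends at a limit (an at least 2.0-fold higher number from compound 1 to compound 2 (0.31 log units; beyond the scatter)). Only the first resembles the new change, so no move beyond the scatter is expected in this assay (expected: a 1.0-fold lower number from compound 3 to compound 4 (0.02 log units; within the scatter)). For compound 4 the estimated value is 24000 nM (expected range 12000 nM to 46000 nM).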

Compound 4, half-maximal cytotoxic concentration: 28000 nM
For compound 4 the middle estimate is 1.2-fold (0.07 log units) below the measured one, within the range that was stated.
By their numbers in this assay, from the lowest: compounds 1, 3 and 4 (each within the scatter of the next). At a limit, above all of these: compound 2.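

In this assay, methyl in place of hydrogen on the amide-type nitrogen gives a 1.1-fold higher number from compound 3 to compound 4 (0.05 log units; within the scatter), so removing the amide hydrogen produces no move beyond the scatter. Dimethylamino in place of methyl on the carbonyl carbon likewise stays within the scatter, with a 1.2-fold higher number from compound 1 to compound 4 (0.07 log units; within the scatter). Compound 2 stands at a limit of the assay, so its comparison gives only a floor: an at least 1.7-fold lower number from compound 2 to compound 4 (0.25 log units; that floor lies within the scatter).

Going by these compounds, whether a longer chain such as ethyl on this nitrogen, or a morpholine amide on the carbonyl carbon, would move the number beyond the scatter remains open.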